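The source may report more compounds than this note shows. Statements on the series, on what has been measured and on what is new or still open speak of the compounds shown alone.

Compound 3 `Cc1cccc(NC(=O)NC2CC(C)(C)Oc3ccc(F)cc32)c1` carries a 3-methylphenyl on the amide-type nitrogen. In a functional assay (aorta) with Rattus norvegicus as the target (on this read-out lower numbers stand for an effect already at smaller amounts and higher numbers for an effect only at larger amounts of compound), compound 3 gives only a limit, > 30000 nM. Compound 1 `COc1cccc(NC(=O)NC2CC(C)(C)Oc3ccc(F)cc32)c1` also sits at a limit in this assay, namely > 10000 nM. Compound 2 `Cc1ccccc1NC(=O)NC1CC(C)(C)Oc2ccc(F)cc21` likewise returns only a limit in this assay, > 30000 nM. The three steps, a step that the two limits leave unreadable from compound 1 to compound 2, a step that the two limits leave unreadable from compound 1 to compound 3 and a step that the two limits leave unreadable from compound 2 to compound 3, are therefore unreadable: two values rest at the limit of > 30000 nM in this assay, at which 2 of the 3 values shown sit, and one at the limit of > 10000 nM in this assay, at which 1 of the 3 values shown sits. Compound 4 `CC1(C)CC(NC(=O)Nc2ccc(Cl)cc2)c2cc(F)ccc2O1` differs by 4-chlorophenyl in place of 3-methylphenyl on an amide-type nitrogen. No readable step among the measured compounds bears on this change, so no direction can be drawn. The expected step of a number no higher from compound 3 to compound 4 (the limit leaves the size open) rests only on the limits. Compound 4 is accordingly estimated at 30000 nM, within 5000 nM to 100000 nM, most likely again a limit.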

Compound 4, half-maximal effective concentration: > 30000 nM
Compound 4: a limit, no number; the forecaster's own chance of this, stated with the estimate: 80%; the middle value sits exactly at the limit.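

In this assay compound 4 gives only a limit, > 30000 nM. Its steps from compound 1, compound 2 and compound 3 therefore cannot be read. The compounds shown leave open whether any group on the amide-type nitrogen gives a readable number in this assay.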